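A few compounds are considered here, and "the series" means these few. Any claim that something is new, unique, unknown or untested is made for them only; others in the source may bear on it.

Going by the values given here, compound 1 `CCCCN(CCC)c1nc(C)nc2c(-c3c(C)cc(N(C)C)nc3C)c(C)nn12` holds the higher of the two numbers so far: in an assay on cell membranes for displacement of a labelled ligand from corticotropin-releasing factor receptor 1 (Rattus norvegicus) (a lower number here means a stronger inhibitor, a higher number a weaker inhibitor), compound 1 gives 12.8 nM, while compound 2 `CCCCN(CCC)c1nc(C)nc2c(-c3ccc(OC)nc3C)c(C)nn12` gives 2.4 nM. Compound 3 `CCCCN(CC)c1nc(C)nc2c(-c3c(C)cc(N(C)C)nc3C)c(C)nn12` differs from compound 1 by a single small change, (hydrogen in place of methyl on a saturated chain carbon, two bonds along the chain from a nitrogen on an aromatic ring). Among the compounds with values here, no measured pair shows this same change, so nothing yet tells its size. The step of a 1.2-fold higher number from compound 1 to compound 3 (0.07 log units; within the scatter) is expected to stay within the scatter, with no clear direction. The estimate for compound 3 in this assay is 15 nM, ranging from 6 nM to 40 nM.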

Compound 3, half-maximal inhibitory concentration: 32.8 nM
The estimate for compound 3 lay 2.2-fold (0.34 log units) below the measured number; the range from low to high includes it.
By their numbers in this assay, from the lowest: compound 2; then compound 1; then compound 3.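

Going from butyl(propyl)amino to butyl(ethyl)amino gives a 2.6-fold higher number from compound 1 to compound 3 (0.41 log units; beyond the scatter) in this assay, so compound 3 is the weaker inhibitor. Removing one carbon from this chain is therefore enough to move the number beyond the usual scatter, which makes the chain length at this position matter. Nothing available explains why this happens.

As far as these compounds go, whether the number keeps rising with a still shorter methyl group remains open. So does whether a longer pentyl chain or a branched cyclopropylmethyl group at this position would lower it.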